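This account rests on a few compounds, and the source may have more. Where it says the series, first, only, none or still open, it means among the compounds named here.

Measured so far in a functional assay on SK-OV-3 cells (Homo sapiens) for antiproliferative activity, read by sulforhodamine B assay, with a stated time of 48 h; on this read-out higher numbers stand for weaker inhibition and lower numbers for stronger inhibition:
compound 1, `COc1cccc(NS(=O)(=O)c2ccc(N3CCNC3=O)cc2)c1` — 240 nM
compound 2, `Cc1cccc(NS(=O)(=O)c2ccc(N3CCNC3=O)cc2)c1` — 200 nM
compound 3, `O=C1NCCN1c1ccc(S(=O)(=O)Nc2cccc(Cl)c2)cc1` — 70 nM

Compound 1 stands at the highest number of the three. Compound 2 lies within the scatter of it, a 1.2-fold lower number from compound 1 to compound 2 (0.08 log units; within the scatter), while compound 3 lies beyond it, a 3.4-fold lower number from compound 1 to compound 3 (0.54 log units; beyond the scatter), and the gap between compound 2 and compound 3 is also beyond the scatter, a 2.9-fold lower number from compound 2 to compound 3 (0.46 log units; beyond the scatter).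

Compound 4, `Cc1ccc(C)c(NS(=O)(=O)c2ccc(N3CCNC3=O)cc2)c1`, differs from compound 1 in 2,5-dimethylphenyl in place of 3-methoxyphenyl on a sulfonamide nitrogen. For the measured compounds named here, the step that bears on this is the one from compound 1 to compound 2, methyl in place of methoxy on an aromatic carbon, which stayed within the scatter. The steps into compound 3 bring in chloro and do not speak to compound 4. Going by the values given here, no measured pair covers the 2,5-dimethylphenyl itself, so what its extra methyl adds is unknown. The expectation is therefore a step of about a 1.3-fold lower number from compound 1 to compound 4 (0.12 log units; within the scatter), within the scatter. Compound 4 is estimated at 180 nM, with a range from 70 nM to 450 nM.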

Compound 4, half-maximal inhibitory concentration: 72 nM
Compound 4: the middle estimate sits 2.5-fold (0.40 log units) above what was measured, and the stated range covers the measured number.
By their numbers in this assay, from the lowest: compounds 3 and 4 (each within the scatter of the next); then compounds 2 and 1 (each within the scatter of the next).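

In this assay, the 2,5-dimethylphenyl on the sulfonamide nitrogen gives a 3.3-fold lower number from compound 1 to compound 4 (0.52 log units; beyond the scatter) against the 3-methoxyphenyl, and the added methyl alone gives a 2.8-fold lower number from compound 2 to compound 4 (0.44 log units; beyond the scatter), so on this aryl group a methyl in place of hydrogen moves the number beyond the scatter, which the exchange of methoxy for methyl did not do. Against the 3-chlorophenyl, the step is a 1.0-fold higher number from compound 3 to compound 4 (0.01 log units; within the scatter), so in this set a chloro is not needed to reach the lower numbers, since an aryl group of carbon only gets there as well. Nothing at hand accounts for the effect of the added methyl.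

Going by these compounds, whether the two methyl groups of compound 4 would add to a chloro on the same aryl group remains open. So does the outcome with an amine, a carboxylic acid or a longer alkyl chain on that ring.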